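This account rests on a few compounds, and the source may have more. Where it says the series, first, only, none or still open, it means among the compounds named here.

Compound 1 `CCC/C=C/C(=O)Nc1cccc(Oc2nc(Nc3cccc(OC)c3)nc3c2CSCC3)c1`: 33800 nM
Compound 2 `COc1cccc(Nc2nc3c(c(Oc4cccc(NC(=O)C=C(C)C)c4)n2)CSCC3)c1`: 19100 nM
Compound 3 `CCC/C=C/C(=O)Nc1cccc(Oc2nc(Nc3cccc(C#N)c3)nc3c2CSCC3)c1`: 7220 nM

These three compounds were tested in a functional assay on HeLa cells (Homo sapiens) for antiproliferative activity, read by MTT assay, with a stated time of 72 h; on this read-out higher numbers stand for weaker inhibition and lower numbers for stronger inhibition. Compound 2 differs from compound 1 by 2-methylprop-1-en-1-yl in place of pent-1-en-1-yl on a carbonyl carbon, and that change gave a 1.8-fold lower number from compound 1 to compound 2 (0.25 log units; within the scatter). Compound 3 differs from compound 1 by cyano in place of methoxy on an aromatic carbon, giving a 4.7-fold lower number from compound 1 to compound 3 (0.67 log units; beyond the scatter); this is also how the core of compound 3 differs from the core shared by compounds 1 and 2.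

Compound 4 `CC(C)=CC(=O)Nc1cccc(Oc2nc(Nc3cccc(C#N)c3)nc3c2CSCC3)c1` has not yet been measured. It differs from compound 3 by 2-methylprop-1-en-1-yl in place of pent-1-en-1-yl on a carbonyl carbon, the same change seen between compounds 1 and 2, at a place described in the same words. Because a 1.8-fold lower number from compound 1 to compound 2 (0.25 log units; within the scatter) was small, a similarly small step is expected, a 1.8-fold lower number from compound 3 to compound 4 (0.26 log units; within the scatter). Compound 4 is therefore estimated at 4000 nM, with a likely range from 2000 nM to 9000 nM.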

Compound 4, half-maximal inhibitory concentration: 29200 nM
Estimate against measurement, compound 4: 7.3-fold (0.86 log units) below, and the stated range ends below it.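

Putting 2-methylprop-1-en-1-yl in place of pent-1-en-1-yl on the carbonyl carbon did not carry over from one core to the other in this assay, where it now gives a 4.0-fold higher number from compound 3 to compound 4 (0.61 log units; beyond the scatter): the same change on two cores in this assay, a 1.8-fold lower number (0.25 log units; within the scatter) from compound 1 to compound 2 and a 4.0-fold higher number (0.61 log units; beyond the scatter) from compound 3 to compound 4, 7.2-fold (0.85 log units) apart, beyond the scatter of two such steps. Cyano in place of methoxy on the aromatic carbon also failed to carry over, giving a 1.5-fold higher number from compound 2 to compound 4 (0.18 log units; within the scatter): the same change on two cores in this assay, a 4.7-fold lower number (0.67 log units; beyond the scatter) from compound 1 to compound 3 and a 1.5-fold higher number (0.18 log units; within the scatter) from compound 2 to compound 4, 7.2-fold (0.85 log units) apart, beyond the scatter of two such steps. In these four compounds, the result of each change therefore depends on which group stands at the other place, but this does not show why, nor whether the same holds for other compounds in the series.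

Going by these compounds, it remains open how a saturated butyl chain or an amine on that carbonyl carbon would behave. The same is true of chlorine in place of cyano on the aromatic carbon.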